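Pyridin-3-yl for 3-chlorophenyl on two cores: solubility

The source may report more compounds than this note shows. Statements on the series, on what has been measured and on what is new or still open speak of the compounds shown alone.

The series is read in a physicochemical assay for solubility, read by LC-MS, using the shake flask method, measured as thermodynamic solubility, with a stated time of 24 h, at pH 6.5; a higher number here means a more soluble compound, a lower number a less soluble compound. Compound 1 `OC[C@H]1O[C@H](n2cc(-c3cccc(Cl)c3)nn2)[C@@H](O)[C@@H](O)[C@@H]1O` gives 705 ug/mL, and compound 2 `OC[C@H]1O[C@H](n2cc(-c3cccnc3)nn2)[C@@H](O)[C@@H](O)[C@@H]1O` gives 1380 ug/mL. The change between them, (pyridin-3-yl in place of 3-chlorophenyl on an aromatic carbon), made the step of a 2.0-fold higher number from compound 1 to compound 2 (0.29 log units; within the scatter), so the two values are taken as equivalent here.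

Compound 3 `OC[C@H]1O[C@H](Cn2cc(-c3cccc(Cl)c3)nn2)[C@@H](O)[C@@H](O)[C@@H]1O` carries the 3-chlorophenyl group on a different core; the difference between the core of compound 1 and the core of compound 3 is not broken down here. In this assay compound 3 reaches only > 3000 ug/mL, which is a limit of the assay and not a number. In this assay there is the limit of > 3000 ug/mL in this assay, at which 1 of the 3 values shown sits, so the measurement for compound 3 gives no position to compare against beyond that limit.

Compound 4 `OC[C@H]1O[C@H](Cn2cc(-c3cccnc3)nn2)[C@@H](O)[C@@H](O)[C@@H]1O` has not yet been measured in this assay. It differs from compound 3 by pyridin-3-yl in place of 3-chlorophenyl on an aromatic carbon, the same change that separates compound 1 from compound 2, at the same place on the same kind of ring.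

For compound 4 the expected step is a step that the limit leaves unreadable from compound 3 to compound 4, which rests on a 2.0-fold higher number from compound 1 to compound 2 (0.29 log units; within the scatter), a step that stayed within the scatter. Compound 4 is estimated at 4500 ug/mL, with a range from 2500 ug/mL to 9000 ug/mL. Since the starting point is itself a limit, compound 4 is expected to be reported as a limit again rather than as a number.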

Compound 4, solubility: 1880 ug/mL
Beside the measured number, compound 4's estimate is 2.4-fold (0.38 log units) above it, outside the stated range (below it).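

In this assay, pyridin-3-yl in place of 3-chlorophenyl gives an at least 1.5-fold lower number from compound 3 to compound 4 (0.20 log units; that floor lies within the scatter) on the core of compound 3, while the same change on the core of compound 1 gives a 2.0-fold higher number from compound 1 to compound 2 (0.29 log units; within the scatter); neither printed step lies beyond the scatter, although the first is only a floor and its full size is not known. The entry for compound 3 is a limit of the assay and not a number: the limit of > 3000 ug/mL in this assay, at which 1 of the 4 values shown sits. For the compounds shown here, these two pairs therefore show that the change can be made on both cores with no step printed as beyond the scatter, but they do not show that it carries over with the same size or the same direction, nor that the two cores respond differently to it.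

The compounds shown contain only 3-chlorophenyl and pyridin-3-yl at this place on the five-membered aromatic ring with 3 nitrogen, so a primary amine or a carboxylic acid on that aromatic ring remains open on either core. Also open, on these data alone, is whether another pair on the core of compound 3 with both members read as numbers would give a step of full known size for comparison with the pair on the core of compound 1.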